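Purine acetamide series: amide side chain replaced by amine

The source may report more compounds than this note shows. Statements on the series, on what has been measured and on what is new or still open speak of the compounds shown alone.

In a functional assay on the whole organism (Tail, strain ICR) with Mus musculus as the target, in the tail flick test, with a stated time of 30 min, at a dose of 25 umol/kg by the oral route (on this read-out lower numbers stand for a weaker effect and higher numbers for a stronger effect at the one dose given), compound 1 `O=C(CN(c1nc(Cl)nc2[nH]cnc12)C1CC1)N[C@@H](CC(=O)OCc1ccccc1)C(=O)OCc1ccccc1` gives 34.7%, compound 2 `O=C(OCc1ccccc1)[C@@H]1CCCN1C(=O)CN(c1ncnc2c1ncn2C1CCCCO1)C1CC1` gives 32.3%, and compound 3 `NC(=O)C[C@H](NC(=O)CN(c1nc(Cl)nc2[nH]cnc12)C1CC1)C(=O)O` gives 29.7%. Compound 3 carries the lowest of the three numbers, but its gaps to compound 2 and to compound 1 both fall within the scatter, so the three measured compounds read as one level in this assay rather than as a ranked set.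

Compound 4 `NCCCC[C@H](NC(=O)CN(c1nc(Cl)nc2[nH]cnc12)C1CC1)C(=O)O` is not yet measured. It differs from compound 3 in one place: 3-aminopropyl in place of carbamoyl on a saturated chain carbon, two bonds along the chain from an amide-type nitrogen and a carbonyl carbon. Within the data shown here, no pair of measured compounds differs in a single place, so there is no measured step to show what a change of this kind does, and the three measured numbers offer no trend to lean on. The expectation for compound 4 is therefore a result near the present level, with the step of a number 0.3 percentage points higher from compound 3 to compound 4 (within the scatter) expected to stay within the scatter. Compound 4 is estimated at 30%, with a range from 15% to 48%.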

Compound 4, a percentage reported as activity, at one dose (the size of the read-out at that dose, not a potency): 31.2%
Compound 4: middle estimate off by 1.2 percentage points, on the low side; low and high end bracket the measured number.
By their numbers in this assay, from the lowest: compounds 3, 4, 2 and 1 (each within the scatter of the next).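

In this assay, 3-aminopropyl in place of carbamoyl on a saturated chain carbon, two bonds along the chain from an amide-type nitrogen and a carbonyl carbon, gives a number 1.5 percentage points higher from compound 3 to compound 4 (within the scatter). This is the only single-place step shown in the series, and it puts a number on this position: carbamoylmethyl and 4-aminobutyl read as one level here, despite the longer chain ending in an amine. No measured property bears on this result.

Still open, from the compounds shown here alone, is whether a carboxylic acid, a guanidine or a hydroxyl at the end of this chain, or a shorter chain ending in an amine, would give a step beyond the scatter. Going by these compounds, with one dose and one time point, how the same exchange reads at other doses also remains open.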